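A few compounds are considered here, and "the series" means these few. Any claim that something is new, unique, unknown or untested is made for them only; others in the source may bear on it.

Compound 3, `COC(=O)c1sc2cc(C#Cc3cccnc3)cnc2c1N`, is one of three close relatives that share a core and differ only in the aryl group on the triple-bonded carbon. In a functional assay on MCF7 cells (Homo sapiens) for inhibition, read by sulforhodamine B assay, with a stated time of 48 h (a higher number here means a weaker inhibitor of growth, a lower number a stronger inhibitor of growth), compound 3 reaches only a limit of the assay, > 150000 nM, so no number is known for it. Compound 2, `COC(=O)c1sc2cc(C#Cc3ccccc3OC)cnc2c1N`, likewise stops at a limit, giving > 47300 nM in this assay. For the measured compounds named here, compound 1, `COC(=O)c1sc2cc(C#Cc3ccc(N)cc3)cnc2c1N`, is the only one with a measured number: in this assay compound 1 gives 2600 nM. The steps from compound 1 were large: an at least 18-fold higher number from compound 1 to compound 2 (1.25 log units; beyond the scatter) and an at least 57-fold higher number from compound 1 to compound 3 (1.76 log units; beyond the scatter). Between the two limits the picture is blank, since a step that the two limits leave unreadable from compound 2 to compound 3.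

Compound 4, `COC(=O)c1sc2cc(C#Cc3ccc(F)cc3)cnc2c1N`, is not yet measured. Its change from compound 3 is 4-fluorophenyl in place of pyridin-3-yl on a triple-bonded carbon. Going by the values given here, the only readable steps show that the 4-aminophenyl of compound 1 stands apart, while a 2-methoxyphenyl and a pyridin-3-yl both sit at limits. A 4-fluorophenyl carries no amino group, so compound 4 is expected to fall closer to compounds 2 and 3 than to compound 1; the step of an at least 3.7-fold lower number from compound 3 to compound 4 (0.57 log units; beyond the scatter) is the expected outcome. Compound 4 is estimated at 40000 nM, within 8000 nM to 150000 nM.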

Compound 4, concentration for 50% growth inhibition: 29000 nM
Compound 4: the middle estimate sits 1.4-fold (0.14 log units) above what was measured; the range from low to high includes it.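

For the compounds shown here, compound 4 is the first compound here without an amino group to give a measured number rather than a limit in this assay, so growth inhibition with this core does not depend entirely on the 4-aminophenyl. Going by these compounds alone, the amino group still matters, since the single change of fluoro in place of amino on an aromatic carbon gives an 11-fold higher number from compound 1 to compound 4 (1.05 log units; beyond the scatter). The 4-fluorophenyl also separates clearly from the pyridin-3-yl, with an at least 5.1-fold lower number from compound 3 to compound 4 (0.71 log units; beyond the scatter), but its edge over the 2-methoxyphenyl is not established, with an at least 1.6-fold lower number from compound 2 to compound 4 (0.21 log units; that floor lies within the scatter).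

From the compounds shown here alone, it remains open whether a 4-hydroxyphenyl or a 4-(dimethylamino)phenyl on the triple-bonded carbon would perform more like the 4-aminophenyl or the 4-fluorophenyl. Going by these compounds, how a 3-aminophenyl would compare with the 4-aminophenyl is also open.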